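Exchanging One Aromatic Ring on a Shared Core

The source may hold more compounds than are shown below. What is called first, only, known or untested is meant among the compounds shown, and "the series" means these compounds.

Compound 1, with the structure `O=C1c2ccc(OCc3cccc(-c4ccc(C(F)(F)F)cc4F)c3)cc2CN1C1CCCC1`, was submitted to an assay on HEK293 cells for positive allosteric modulation of metabotropic glutamate receptor 2 (Rattus norvegicus), read by thallium flux (on this read-out lower numbers stand for smaller maximal responses and higher numbers for larger maximal responses), yet no result was reported, and compound 1 is therefore recorded as "not determined" (no result reported). Compound 1 thus has no place on the scale of this measurement and serves only as the starting structure. A second measured compound, compound 2 with the structure `CC(C)Cn1sc2cc(OCc3cccc(-c4ccc(Cl)c(C(=O)O)c4)c3)ccc2c1=O`, is built on a different core but carries the same 5-carboxy-2-chlorophenyl group that enters below. In this assay compound 2 gives 76.2%.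

The unmeasured compound 3, `O=C(O)c1ccc(Cl)c(-c2cccc(COc3ccc4c(c3)CN(C3CCCC3)C4=O)c2)c1`, is reached from compound 1 by a single change: 5-carboxy-2-chlorophenyl in place of 2-fluoro-4-(trifluoromethyl)phenyl on an aromatic carbon. From the compounds shown here alone, since compound 1 has no number, neither the size nor the direction of this step in this assay can be read from compound 1 itself, and whether it exceeds the usual scatter remains open. Compound 3 is expected to reach a maximal response near 75%, within a range from 50% to 100%. That expectation rests on compound 2, which gives 76.2% in this assay while bearing the same entering group.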

Compound 3, largest response reached (reported as percent of maximum), in percent of the reference or control that the assay uses: 93.9%
Beside the measured number, compound 3's estimate is 18.9 percentage points below it; the range from low to high includes it.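

Within the data shown here, compound 3 now has a value in this assay, but compound 1 has no single number there, so no step from compound 1 to compound 3 can be read. From the compounds shown here alone, what this exchange of aromatic groups does to the maximal response on a shared core stays open. No measured evidence shown here explains the result for compound 3.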